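This account rests on a few compounds, and the source may have more. Where it says the series, first, only, none or still open, it means among the compounds named here.

In a functional assay on A549 cells (Homo sapiens) for antiproliferative activity, read by CCK-8 assay, with a stated time of 48 h (on this read-out higher numbers stand for weaker inhibition and lower numbers for stronger inhibition), compound 2 `Cc1ccccc1CSc1n[nH]c(-n2[se]c3ccccc3c2=O)n1` gives 9720 nM, the only number shown in this assay. Compound 1 `O=c1c2ccccc2[se]n1-c1nc(SCc2ccccc2)n[nH]1` is a limit case: in this assay compound 1 gives > 50000 nM, a limit and not a number (the limit of > 50000 nM in this assay, at which 1 of the 2 values shown sits). The measured step of an at least 5.1-fold lower number from compound 1 to compound 2 (0.71 log units; beyond the scatter) is therefore an at least modest gain. Compound 3 `CCCSc1n[nH]c(-n2[se]c3ccccc3c2=O)n1` differs from compound 2 by ethyl in place of 2-methylphenyl on a saturated chain carbon bound to a sulfur. Among the measured compounds shown here, no measured step bears on removing the aromatic ring, so the expectation for compound 3 rests on compound 2 alone, and a loss is expected, a 2.3-fold higher number from compound 2 to compound 3 (0.35 log units; beyond the scatter). Compound 3 is estimated at 22000 nM, between 8000 nM and 50000 nM.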

Compound 3, half-maximal inhibitory concentration: 45500 nM
Compound 3: the middle estimate sits 2.1-fold (0.32 log units) below what was measured; low and high end bracket the measured number.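

Replacing 2-methylphenyl with ethyl on a saturated chain carbon bound to a sulfur gives a modest measured loss in this assay: a 4.7-fold higher number from compound 2 to compound 3 (0.67 log units; beyond the scatter). This place therefore responds to more than the added methyl, and the ring-free propyl side chain does not keep the number of compound 2. The step with ethyl in place of phenyl on a saturated chain carbon bound to a sulfur is an at least 1.0-fold lower number from compound 1 to compound 3 (0.04 log units; that floor lies within the scatter), which gives only a floor, since compound 1 is a limit and not a number: the limit of > 50000 nM in this assay, at which 1 of the 3 values shown sits.

The compounds shown leave open whether a longer chain, such as hexyl, would recover activity. As far as these compounds go, an amine at the end of the chain also remains untested here.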